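A few compounds are considered here, and "the series" means these few. Any claim that something is new, unique, unknown or untested is made for them only; others in the source may bear on it.

Of the compounds shown here, three built on one shared core have so far been measured in a functional assay on HepG2 cells (Homo sapiens) for inhibition, read by MTT assay, with a stated time of 72 h; on this read-out higher numbers stand for weaker inhibition and lower numbers for stronger inhibition. Compound 1 `Cn1cc(-c2cnc(N)c(Oc3ccc(C(=O)Nc4ccccc4)cc3)n2)cn1` gives 11600 nM. Compound 2 `Cn1cc(-c2cnc(N)c(Oc3ccc(C(=O)Nc4ccccc4Cl)cc3)n2)cn1` gives 66900 nM, which is a 5.8-fold higher number from compound 1 to compound 2 (0.76 log units; beyond the scatter). Compound 3 `Cn1cc(-c2cnc(N)c(Oc3ccc(C(=O)Nc4cccc(Cl)n4)cc3)n2)cn1` gives 44200 nM, so that a 3.8-fold higher number from compound 1 to compound 3 (0.58 log units; beyond the scatter), while a 1.5-fold lower number from compound 2 to compound 3 (0.18 log units; within the scatter). Compound 3 therefore stands second highest of the three, close to compound 2 and clearly above compound 1. Compound 4 `Cn1cc(-c2cnc(N)c(Oc3ccc(C(=O)Nc4ncccc4Cl)cc3)n2)cn1` differs from compound 3 by 3-chloropyridin-2-yl in place of 6-chloropyridin-2-yl on an amide-type nitrogen. Within the data shown here, the one measured step that compares two chlorine-bearing rings on this nitrogen, a 1.5-fold lower number from compound 2 to compound 3 (0.18 log units; within the scatter), lay within the scatter, so no step beyond the scatter is expected in this assay, namely a 1.1-fold higher number from compound 3 to compound 4 (0.05 log units; within the scatter). Compound 4 is accordingly estimated at 50000 nM, within 20000 nM to 120000 nM.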

Compound 4, half-maximal inhibitory concentration: 21700 nM
Compound 4: the middle estimate sits 2.3-fold (0.36 log units) above what was measured; low and high end bracket the measured number.
By their numbers in this assay, from the lowest: compounds 1 and 4 (each within the scatter of the next); then compounds 3 and 2 (each within the scatter of the next).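

In this assay, the same atoms joined differently already give a step beyond the scatter, so the place of the chlorine on the pyridine ring matters here (a 2.0-fold lower number from compound 3 to compound 4 (0.31 log units; beyond the scatter)). The 3-chloropyridin-2-yl group also separates from 2-chlorophenyl (a 3.1-fold lower number from compound 2 to compound 4 (0.49 log units; beyond the scatter)), yet stays within the scatter of the plain phenyl (a 1.9-fold higher number from compound 1 to compound 4 (0.27 log units; within the scatter)). Nothing available explains these differences. Still open, as far as these compounds go, is how pyridin-2-yl without chlorine, or 3-methoxypyridin-2-yl or 3-aminopyridin-2-yl, would read on this amide-type nitrogen.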